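Replacing 4-nitrophenyl on the amide-type nitrogen

This account rests on a few compounds, and the source may have more. Where it says the series, first, only, none or still open, it means among the compounds named here.

Measured in an ADME assay on MT4 cells (Homo sapiens) for cytotoxicity, read by MTT assay, with a stated time of 5 days; a lower number here means that less compound is tolerated, a higher number that more compound is tolerated:
- compound 1 `Cc1cc(OCC(=O)Nc2ccc(Cl)cc2)nc(Nc2ccc(C#N)cc2)n1`: 2630 nM
- compound 2 `Cc1cc(OCC(=O)Nc2ccc([N+](=O)[O-])cc2)nc(Nc2ccc(C#N)cc2)n1`: > 309000 nM (a limit)

Compound 2 stands at the limit of > 309000 nM in this assay, at which 1 of the 2 values shown sits, so it has a limit and not a number. Compound 3 `Cc1cc(OCC(=O)Nc2ccc(C#N)cc2F)nc(Nc2ccc(C#N)cc2)n1` has 4-cyano-2-fluorophenyl in place of 4-nitrophenyl on an amide-type nitrogen. Among the measured compounds shown here, the only measured step at this phenyl group is large: an at least 110-fold higher number from compound 1 to compound 2 (2.07 log units; beyond the scatter). Compound 3 keeps neither the chloro nor the nitro group, so a lower number is expected in this assay, with wide uncertainty. The expected move is an at least 10-fold lower number from compound 2 to compound 3 (1.01 log units; beyond the scatter). For compound 3 the estimate is 30000 nM, with a range of 3000 nM to 300000 nM.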

Compound 3, half-maximal cytotoxic concentration: > 310000 nM
Compound 3: a limit, no number (the forecaster's own chance of this, stated with the estimate: 30%); middle value at least 10-fold (1.01 log units) away from the limit.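

In this assay compound 3 gives > 310000 nM, a limit. Compound 2 also carries a limit, and the step between these two cannot be read. Among the compounds shown here, with 4-cyano-2-fluorophenyl in place of 4-chlorophenyl on the amide-type nitrogen, the result is an at least 110-fold higher number from compound 1 to compound 3 (2.07 log units; beyond the scatter), so 4-nitrophenyl is no longer the only group at this position with a large step away from the chloro compound.

Whether the lower number belongs to the chloro group itself stays open, since only one chloro compound is shown. A plain phenyl, 4-methoxyphenyl or 4-aminophenyl group on this nitrogen would bear on that question.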